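A few compounds are considered here, and "the series" means these few. Any claim that something is new, unique, unknown or untested is made for them only; others in the source may bear on it.

Measured so far in a functional assay on BMDM cells (Mus musculus, strain C57BL/6) for inhibition, with a stated time of 2 days; on this read-out lower numbers stand for stronger inhibition and higher numbers for weaker inhibition:
compound 1 `O=C(Cn1cc(-c2ccc(F)cc2)nn1)Nc1nccs1`, 190 nM;
compound 2 `Cc1cc(NC(=O)Cn2cc(-c3ccc(F)cc3)nn2)no1`, reported only as a limit of the assay, > 30000 nM;
compound 3 `O=C(Cn1cc(-c2ccc([N+](=O)[O-])cc2)nn1)Nc1nccs1`, 1040 nM.

Compound 1 holds the lowest of the two numbers shown; compound 3 is nearest, with a 5.5-fold higher number from compound 1 to compound 3 (0.74 log units; beyond the scatter). The change on the amide-type nitrogen, an at least 150-fold higher number from compound 1 to compound 2 (2.19 log units; beyond the scatter), ends at the limit (the limit of > 30000 nM in this assay, at which 1 of the 3 values shown sits), so its size is known only as a floor.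

Compound 4 `O=C(Cn1cc(-c2ccncc2)nn1)Nc1nccs1` has not yet been run; it differs from compound 1 by pyridin-4-yl in place of 4-fluorophenyl on an aromatic carbon. Within the data shown here, of the measured steps, only the one that alters the six-membered aromatic ring of carbon only bears on this change: a 5.5-fold higher number from compound 1 to compound 3 (0.74 log units; beyond the scatter), a modest loss. Among the measured compounds shown here, replacing that ring with pyridin-4-yl is a different alteration, and no measured step tests it directly, so the size is uncertain; a modest rise in the number in this assay, of about the same order as the nitro step or smaller, is expected.

Compound 4 is therefore expected near 550 nM, with a range of 150 nM to 2500 nM. The expected step is a 2.9-fold higher number from compound 1 to compound 4 (0.46 log units; beyond the scatter), toward weaker inhibition.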

Compound 4, half-maximal inhibitory concentration: 2 nM
Beside the measured number, compound 4's estimate is 280-fold (2.44 log units) above it; measured number outside the range, below it.
By their numbers in this assay, from the lowest: compound 4; then compound 1; then compound 3. At a limit, above all of these: compound 2.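

In this assay, pyridin-4-yl in place of 4-fluorophenyl gives a 95-fold lower number from compound 1 to compound 4 (1.98 log units; beyond the scatter), so this aromatic carbon of the five-membered ring is a place where a change can strongly lower the number, not only raise it. The earlier change here, nitro in place of fluoro, went the other way, with a 5.5-fold higher number from compound 1 to compound 3 (0.74 log units; beyond the scatter), so the three compounds 1, 3 and 4 now show movement in both directions at this one position. Nothing shown gives a cause for the new step.

Still open, going by these compounds, is whether the gain depends on where the ring nitrogen sits, as pyridin-3-yl or pyridin-2-yl would show, or survives a second ring nitrogen, as in pyrimidin-4-yl. Also open, on these data alone, is whether pyridin-4-yl works with amide-nitrogen groups other than 1,3-thiazol-2-yl.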